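The source may hold more compounds than are shown below. What is called first, only, known or untested is meant among the compounds shown, and "the series" means these compounds.

compound 1 `O=C(/C=C/c1ccc(O)c(O)c1)N1CCN(c2ccccc2F)CC1` gives 1.43 ug/mL
compound 2 `O=C(/C=C/c1ccc(O)c(O)c1)N1CCN(c2ccc(F)cc2)CC1` gives 1.25 ug/mL
compound 3 `COc1cccc(N2CCN(C(=O)/C=C/c3ccc(O)c(O)c3)CC2)c1` gives 1.27 ug/mL

In a functional assay on A549 cells (Homo sapiens) for antiproliferative activity, read by MTT assay, with a stated time of 48 h (on this read-out higher numbers stand for weaker inhibition and lower numbers for stronger inhibition), compound 3 lies within the scatter of both compound 1 and compound 2, so no order can be read among the three. Compound 4 `COc1ccc(N2CCN(C(=O)/C=C/c3ccc(O)c(O)c3)CC2)cc1` is unmeasured; it carries 4-methoxyphenyl in place of 3-methoxyphenyl on an amine nitrogen in a ring. Three measured aryl swaps at that place bear on this: a 1.1-fold lower number from compound 1 to compound 2 (0.06 log units; within the scatter), a 1.1-fold lower number from compound 1 to compound 3 (0.05 log units; within the scatter) and a 1.0-fold higher number from compound 2 to compound 3 (0.01 log units; within the scatter). Each lies within the scatter, so no real shift in this assay is expected in either direction. The expected change is a 1.0-fold higher number from compound 3 to compound 4 (0.01 log units; within the scatter). For compound 4 the estimated value is 1.3 ug/mL, with an expected range of 0.7 ug/mL to 2.4 ug/mL.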

Compound 4, half-maximal inhibitory concentration: 0.93 ug/mL
The estimate for compound 4 lay 1.4-fold (0.15 log units) above the measured number; low and high end bracket the measured number.
By their numbers in this assay, from the lowest: compounds 4, 2, 3 and 1 (each within the scatter of the next).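

In this assay, 4-methoxyphenyl in place of 3-methoxyphenyl on the amine nitrogen gives a 1.4-fold lower number from compound 3 to compound 4 (0.14 log units; within the scatter) and so adds a second placement of methoxy to the flat picture at this position. Methoxy in place of fluoro on an aromatic carbon gives a 1.3-fold lower number from compound 2 to compound 4 (0.13 log units; within the scatter) and 4-methoxyphenyl in place of 2-fluorophenyl gives a 1.5-fold lower number from compound 1 to compound 4 (0.19 log units; within the scatter) and thus all four aryl groups remain within the scatter of one another. No supporting data bear on this result. From the compounds shown here alone, whether a carboxylic acid or an amine on that phenyl group would shift the number beyond the scatter stays open.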